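The source may report more compounds than this note shows. Statements on the series, on what has been measured and on what is new or still open speak of the compounds shown alone.

In an ADME assay on microsomes from liver (Homo sapiens) for metabolic stability (a higher number here means faster removal of the compound, a lower number slower removal), compound 1 `CC(=O)N[C@@H]1CCC[C@H](C(=O)Nc2cc(-c3cnn4c3CCCC4)c(Cl)cn2)C1` gives 17 mL.min-1.g-1 and compound 3 `CC(=O)N[C@@H]1CCC[C@H](C(=O)Nc2cc(-c3cnn4c3NCCC4)c(Cl)cn2)C1` gives 6.2 mL.min-1.g-1, the lower of the two actual numbers. Compound 2 `CC(=O)N[C@@H]1CCC[C@H](C(=O)Nc2cc(-c3cnn4c3CCC4)c(Cl)cn2)C1` reports only a limit of the assay, < 3 mL.min-1.g-1. The next structure, compound 4 `CC(=O)N[C@@H]1CCC[C@H](C(=O)Nc2cc(-c3cnn4c3OCCC4)c(Cl)cn2)C1`, arises through (a group of 9 heavy atoms (6 carbon, 2 nitrogen, 1 oxygen; one five-membered aromatic ring with 2 hetero atoms, one six-membered non-aromatic ring with 2 hetero atoms) in place of a group of 9 heavy atoms (6 carbon, 3 nitrogen; one five-membered aromatic ring with 2 hetero atoms, one six-membered non-aromatic ring with 2 hetero atoms), on an aromatic carbon), on an aromatic carbon, and both groups keep one five-membered aromatic ring and one six-membered non-aromatic ring. Going by the values given here, the closest precedent is a 2.7-fold lower number from compound 1 to compound 3 (0.44 log units; beyond the scatter), since that step also exchanges one group of the same heavy-atom count for another. The other two steps, an at least 5.6-fold lower number from compound 1 to compound 2 (0.75 log units; beyond the scatter) and an at least 2.0-fold higher number from compound 2 to compound 3 (0.31 log units; beyond the scatter), change the heavy-atom count and rest on a limit, so they bear on it less. Among the compounds with values here, no measured step swaps these two groups directly, so no clear direction can be drawn, and only a small upward drift towards compound 1 at 17 mL.min-1.g-1 is allowed for. The expected change is a 1.3-fold higher number from compound 3 to compound 4 (0.11 log units; within the scatter), which is no step beyond the scatter. Compound 4 is estimated at 8 mL.min-1.g-1, with an expected range from 3.5 mL.min-1.g-1 to 18 mL.min-1.g-1.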

Compound 4, intrinsic clearance in microsomes in the Homo sapiens assay: < 3 mL.min-1.g-1
Compound 4: only a limit was reported; the forecaster's own chance of this, stated with the estimate: 10%; middle value at least 2.6-fold (0.42 log units) from the limit.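

In the Homo sapiens assay, the oxygen-bearing group, which has no hydrogen-bond donor, replaces the nitrogen-bearing group in an at least 2.0-fold lower number from compound 3 to compound 4 (0.31 log units; beyond the scatter), and the comparison with the carbon-only six-membered ring gives an at least 5.6-fold lower number from compound 1 to compound 4 (0.75 log units; beyond the scatter). Compound 4 stands at a limit of the assay, as does compound 2, so the step between those two cannot be read: the limit of < 3 mL.min-1.g-1 in the Homo sapiens assay, at which 2 of the 4 values shown sit. In a physicochemical assay for solubility, in phosphate buffer, at pH 7.4 (a higher number here means a more soluble compound, a lower number a less soluble compound), compound 3 gives 860000 nM and compound 4 gives 110000 nM. At the same position, the exchange carries a cost in the physicochemical assay: the measured solubility of compound 3, 860000 nM, and of compound 4, 110000 nM, a 7.8-fold lower number (0.89 log units; beyond the scatter).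

The limit leaves open how much slower the removal of compound 4 is in the Homo sapiens assay. From the compounds shown here alone, it also remains open whether a sulfur atom or a methyl-substituted ring nitrogen in the same place would keep slow removal in the Homo sapiens assay while giving up less in the physicochemical assay.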